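The source may report more compounds than this note shows. Statements on the series, on what has been measured and on what is new or still open speak of the compounds shown alone.

Measured in an assay on HEK293 cells for positive allosteric modulation of metabotropic glutamate receptor 3 (Rattus norvegicus), read by thallium flux, with a stated time of 2.5 min; on this read-out lower numbers stand for smaller maximal responses and higher numbers for larger maximal responses:
compound 1 `CCC(=O)c1ccc(OCCCCOc2ccc(F)c(C(=O)O)c2)c(C)c1O`: 18.4%
compound 2 `Cc1c(OCCCCOc2ccc(F)c(C(=O)O)c2)ccc(C(=O)CC2CCCC2)c1O`: 98.4%
compound 3 `COC(=O)c1ccc(OCCCCOc2ccc(C(=O)CC3CCCC3)c(C)c2C)cc1`: 24.2%

Compound 2 gives the highest of the three numbers; compound 3 lies nearest to it and compound 1 furthest, both beyond the scatter. Compound 4 `Cc1cc(OCCCCOc2ccc(C(=O)CC3CCCC3)c(O)c2C)ccc1C(=O)O` carries 4-carboxy-3-methylphenyl in place of 3-carboxy-4-fluorophenyl on an oxygen on a saturated carbon. Among the measured compounds shown here, the one measured step, a number 80 percentage points higher from compound 1 to compound 2 (beyond the scatter), concerns the cyclopentyl and does not bear on this change, and no measured pair isolates an exchange of the aryl acid. Compound 3, which also carries the cyclopentyl but a different aryl group and a differently arranged core, reaches a far lower value than compound 2, so the aryl part is not indifferent. Compound 4 is therefore expected to lie lower, by an estimated a number 28.4 percentage points lower from compound 2 to compound 4 (beyond the scatter). The estimate for compound 4 in this assay is 70%, within 35% to 100%.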

Compound 4, largest response reached (reported as percent of maximum), in percent of the reference or control that the assay uses: 23.7%
The estimate for compound 4 lay 46.3 percentage points above the measured number; the measured number lies below the stated range.
By their numbers in this assay, from the lowest: compounds 1, 4 and 3 (each within the scatter of the next); then compound 2.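

In this assay, placing 4-carboxy-3-methylphenyl in place of 3-carboxy-4-fluorophenyl on an oxygen on a saturated carbon gives a number 74.7 percentage points lower from compound 2 to compound 4 (beyond the scatter), so this aryl acid is not interchangeable at this place. The cyclopentyl present in both compounds therefore does not by itself secure a large maximal response. Nothing available explains the drop. From the compounds shown here alone, the exchange alters both the carboxylic acid's place and the fluorine together, so their separate contributions remain open. Also open, going by these compounds, is how a chlorine in place of the fluorine, or a tetrazole in place of the carboxylic acid, would read out.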